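The compounds below may be only part of what the source reports. "The series", "measured", "known", "first", "only" and "open" are said of these compounds alone.

Values so far in a functional assay on CCRF-CEM cells (Homo sapiens) for cytotoxicity, read by XTT assay, with a stated time of 3 days; a lower number here means a stronger inhibitor, a higher number a weaker inhibitor
- compound 1 `OC[C@H]1O[C@@H](n2cc(F)c3c(-c4ccccc4)ncnc32)[C@H](O)[C@@H]1O` gives 3100 nM
- compound 2 `OC[C@H]1O[C@@H](n2cc(F)c3c(-c4ccoc4)ncnc32)[C@H](O)[C@@H]1O` gives 1000 nM

Compound 2 holds the lower of the two numbers, and the gap to compound 1 lies beyond the scatter. Going by the values given here, that gap is the only measured step, a modest one (a 3.1-fold lower number from compound 1 to compound 2 (0.49 log units; beyond the scatter)), with furan-3-yl in place of phenyl on an aromatic carbon.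

The next compound is compound 3 `OC[C@H]1O[C@@H](n2cc(F)c3c(-c4cc[nH]c4)ncnc32)[C@H](O)[C@@H]1O` with 1H-pyrrol-3-yl in place of furan-3-yl on an aromatic carbon. The group sits on the six-membered aromatic ring with 2 nitrogen, and the rest of the structure stays the same.

The measured step bears on this change only indirectly, since it swaps a different pair of groups. It shows that the number can move with the group at this place. Here, one five-membered aromatic ring with 1 hetero atom replaces another, so no step beyond the scatter is expected in this assay, and no direction is clearly favoured. The expectation starts from compound 2 at 1000 nM and the range is kept wide, as no pyrrole has been measured yet. The expected step is small (a 1.3-fold lower number from compound 2 to compound 3 (0.10 log units; within the scatter)). The estimated value for compound 3 is 800 nM (range 200 nM to 3000 nM).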

Compound 3, half-maximal inhibitory concentration: 930 nM
The estimate for compound 3 lay 1.2-fold (0.07 log units) below the measured number; the range from low to high includes it.
By their numbers in this assay, from the lowest: compounds 3 and 2 (each within the scatter of the next); then compound 1.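

In this assay, 1H-pyrrol-3-yl and furan-3-yl cannot be told apart at this place on the six-membered aromatic ring with 2 nitrogen (a 1.1-fold lower number from compound 2 to compound 3 (0.03 log units; within the scatter)), although the exchange puts a ring nitrogen in place of a ring oxygen and a hydrogen-bond donor in place of a hydrogen-bond acceptor. The difference from phenyl therefore no longer rests on furan-3-yl alone: the second five-membered aromatic ring with 1 hetero atom also stands apart from the phenyl of compound 1 (a 3.3-fold lower number from compound 1 to compound 3 (0.52 log units; beyond the scatter)), so in these three compounds the hetero atom's identity leaves the number unchanged within the scatter. No supporting measurement is available to explain either step.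

Still open, on these data alone, is whether the result extends to thiophen-3-yl, to furan-2-yl or 1H-pyrrol-2-yl, which attach through a different ring carbon, or to a pyrrole carrying a methyl group on its nitrogen. Also open, as far as these compounds go, is how a non-aromatic group at this place, such as an amine or a longer alkyl chain, would compare with the aromatic rings.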